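Two thiazole acetic acids and a third awaiting its efficacy

A few compounds are considered here, and "the series" means these few. Any claim that something is new, unique, unknown or untested is made for them only; others in the source may bear on it.

Measured so far:
compound 1, `O=C(O)Cc1sc(C(c2ccc(F)cc2)c2ccc(F)cc2)nc1-c1ccoc1`, 80%
compound 2, `O=C(O)Cc1sc(C(c2ccccc2)c2ccccn2)nc1-c1ccc(Cl)cc1`, 55%

In an in vitro functional assay on HEK285-7 cells for antagonist activity at prostaglandin D2 receptor 2 (Homo sapiens), read by BRET and beta-arrestin recruitment (on this read-out lower numbers stand for smaller maximal responses and higher numbers for larger maximal responses), compound 1 gives 80%. Among the measured compounds shown here, compound 1 stands highest of the two numbers known; the nearest is compound 2, whose value in this assay is 55%, a gap that lies beyond the scatter of repeated measurements. The two compounds differ in more than one place, so their pair says only what the two values show, and no single change can be read from them.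

Compound 3, `Nc1cc(-c2nc(C(c3ccc(F)cc3)c3ccc(F)cc3)sc2CC(=O)O)cc(F)n1`, has not yet been measured in this assay. It differs from compound 1 in one place: 2-amino-6-fluoropyridin-4-yl in place of furan-3-yl on an aromatic carbon.

For the measured compounds named here, no step between measured compounds covers this change, so the size of the step from compound 1 to compound 3 rests on expectation alone. The account expects a step of a number 10 percentage points lower from compound 1 to compound 3 (within the scatter) in this assay, a modest lowering that may yet fall within the scatter. For compound 3 the expected value in this assay is 70%, with a range from 45% to 95%.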

Compound 3, largest response reached (reported as efficacy), in percent of the reference or control that the assay uses: 30%
For compound 3 the middle estimate is 40 percentage points above the measured one; measured number below the stated range.
By their numbers in this assay, from the lowest: compound 3; then compound 2; then compound 1.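

Within this assay the exchange of furan-3-yl for 2-amino-6-fluoropyridin-4-yl, on the aromatic carbon next to the ring nitrogen and next to the ring atom that bears a carboxymethyl group, gives a number 50 percentage points lower from compound 1 to compound 3 (beyond the scatter) and so supplies the first reading of a single change in this series. It shows that this position is not indifferent: with the bis(4-fluorophenyl)methyl side and the carboxymethyl group held constant, the group on this carbon alone moves the maximal response by more than the usual scatter, something the earlier pair, which differs in more than one place, could not show. No measurement shown here accounts for the size of this step.

The exchange alters the ring, the amine and the fluorine together, so the compounds shown do not tell which part of the entering group goes with the lower number. As far as these compounds go, how a plain pyridin-4-yl, a 2-aminopyridin-4-yl, a 2-fluoropyridin-4-yl or a thiophen-3-yl would stand on this carbon remains open, as does whether the same exchange would give a step of like size on the core of compound 2 .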